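Glycine transporter 1 series: aryl versus oxane carbonyl

The compounds below may be only part of what the source reports. "The series", "measured", "known", "first", "only" and "open" are said of these compounds alone.

Measured so far:
compound 1, `CC(C(=O)Nc1cc(F)cc(F)c1)N(C(=O)c1ccc(Cl)cc1)C1CCCCC1`, 3980 nM
compound 2, `O=C(CCN(C(=O)c1ccc(Cl)cc1)C1CCCCC1)Nc1cc(F)cc(F)c1`, 10000 nM
compound 3, `O=C(CN(C(=O)C1CCOCC1)C1CCCCC1)Nc1cc(F)cc(F)c1`, 5010 nM

All three numbers come from an assay on HEK293 cells for inhibition of sodium- and chloride-dependent glycine transporter 1 (Homo sapiens), read by scintillation proximity assay; on this read-out higher numbers stand for weaker inhibition and lower numbers for stronger inhibition. Compound 3 sits second highest of the three; its gap to compound 1 and its gap to compound 2 both lie within the scatter, so no order among the three is claimed.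

Compound 4, `O=C(CN(C(=O)c1cccc(Cl)c1)C1CCCCC1)Nc1cc(F)cc(F)c1`, has not been measured. Relative to compound 3 the change is 3-chlorophenyl in place of oxan-4-yl on a carbonyl carbon. Going by the values given here, no step between measured compounds isolates this change: compounds 1 and 2 differ from compound 4 in more than one place, so their values only show that a chlorinated aromatic ring on this carbonyl is compatible with numbers in the same weak range as compound 3.

On that basis the step from compound 3 to compound 4 is expected to be small, at most a modest move towards a lower number, a 1.6-fold lower number from compound 3 to compound 4 (0.19 log units; within the scatter). Compound 4 is accordingly estimated at 3200 nM, with a range from 1000 nM to 12000 nM.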

Compound 4, half-maximal inhibitory concentration: 1580 nM
Compound 4: middle estimate off by 2.0-fold (0.31 log units), on the high side; low and high end bracket the measured number.
By their numbers in this assay, from the lowest: compound 4; then compounds 1, 3 and 2 (each within the scatter of the next, the first and the last beyond it).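

Going by these compounds alone, compound 3 and compound 4 form the first pair that differs in one place, so the group on this carbonyl carbon can now be read on its own, with the rest of the molecule held fixed. Replacing oxan-4-yl with 3-chlorophenyl gives a 3.2-fold lower number from compound 3 to compound 4 (0.50 log units; beyond the scatter), showing that the number responds to this group, although the step is only modest. Nothing at hand indicates what in the exchange of the two rings accounts for the step.

The compounds shown do not separate the contribution of the aromatic ring from that of the chlorine, so an unsubstituted phenyl on this carbonyl carbon would be the informative comparison. Also open, on these data alone, is how a basic amine such as piperidin-4-yl or a carboxylic acid on the same ring would read here.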